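A sulfonyl swap in a low-inhibition phosphodiesterase series

This account rests on a few compounds, and the source may have more. Where it says the series, first, only, none or still open, it means among the compounds named here.

Compound 1 `Cn1c(N)nc2c1c(=O)n(CC1CC1)c(=O)n2CC1CC1` and compound 2 `Nc1nc2c(c(=O)n(CC3CC3)c(=O)n2CC2CC2)n1Cc1ccc([N+](=O)[O-])cc1` share a common core; in an assay on isolated protein with dual specificity calcium/calmodulin-dependent 3',5'-cyclic nucleotide phosphodiesterase 1B (Bos taurus) as the target, tested at 100 uM (on this read-out lower numbers stand for less inhibition and higher numbers for more inhibition at the one concentration tested (going by the name of the read-out)), compound 1 gives 30%. Compound 2 gives 30%, and no change at the digits printed from compound 1 to compound 2 (within the scatter). Compound 3 `Nc1nc2c(c(=O)n(CC3CC3)c(=O)n2CC2CC2)n1S(=O)(=O)c1ccc(Cl)cc1` gives 1% in this assay, the lowest of the three numbers, with a number 29 percentage points lower from compound 1 to compound 3 (beyond the scatter) and a number 29 percentage points lower from compound 2 to compound 3 (beyond the scatter). Compound 4 `COc1ccc(S(=O)(=O)n2c(N)nc3c2c(=O)n(CC2CC2)c(=O)n3CC2CC2)cc1OC` differs from compound 3 by 3,4-dimethoxyphenyl in place of 4-chlorophenyl on a sulfonyl sulfur. Among the measured compounds shown here, no measured step changes the group on the sulfonyl sulfur, so the two steps into compound 3 only show that the sulfonyl compounds sit low. Compound 4 is therefore expected to stay near that low level, with a number 4 percentage points higher from compound 3 to compound 4 (within the scatter) not beyond the scatter. The estimate for compound 4 is 5%, in a range from -10% to 25%.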

Compound 4, a percentage reported as inhibition, at one concentration (the size of the read-out at that concentration, not a potency): 56%
Compound 4: middle estimate off by 51 percentage points, on the low side; the whole stated range lies below it.
By their numbers in this assay, from the lowest: compound 3; then compounds 1 and 2 (each within the scatter of the next); then compound 4.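

In this assay the group on the sulfonyl sulfur matters greatly, since 3,4-dimethoxyphenyl in place of 4-chlorophenyl gives a number 55 percentage points higher from compound 3 to compound 4 (beyond the scatter). A sulfonyl group on the aromatic nitrogen therefore does not by itself mean a low number, as the two earlier steps into compound 3 might have suggested. Nothing available explains this rise. On these data alone, it remains open whether both methoxy groups are needed or one would give a similar number. Also open, as far as these compounds go, is how an amine or a carboxylic acid on the phenyl ring would behave.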